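This account rests on a few compounds, and the source may have more. Where it says the series, first, only, none or still open, it means among the compounds named here.

Compound 1 `O=c1c2c(Nc3ccccc3)nn(-c3ccccc3)c2nc(Nc2ccccc2)n1-c1ccccc1` is the point of comparison. In a functional assay on the whole organism (strain Wistar albino) for inhibition, with Rattus norvegicus as the target, read by paw edema, with a stated time of 2 h, at a dose of 25 mg/kg by the oral route (a higher number here means more inhibition at the dose given (going by the name of the read-out), a lower number less inhibition), compound 1 gives 43.4%. Compound 2 `NS(=O)(=O)c1ccc(-n2nc(Nc3ccccc3)c3c(=O)n(-c4ccccc4)c(Nc4ccccc4)nc32)cc1` differs from it by sulfamoyl in place of hydrogen on an aromatic carbon; in this assay compound 2 gives 54.8%, a step of a number 11.4 percentage points higher from compound 1 to compound 2 (beyond the scatter). Compound 3 `O=c1c2c(Nc3ccc([N+](=O)[O-])cc3)nn(-c3ccccc3)c2nc(Nc2ccccc2)n1-c1ccccc1` gives 29% in this assay, a step of a number 14.4 percentage points lower from compound 1 to compound 3 (beyond the scatter), and it stands lowest of the three. Compound 4 `NS(=O)(=O)c1ccc(-n2nc(Nc3ccc([N+](=O)[O-])cc3)c3c(=O)n(-c4ccccc4)c(Nc4ccccc4)nc32)cc1` has not yet been measured. It differs from compound 3 by sulfamoyl in place of hydrogen on an aromatic carbon, the same change that was made from compound 1 to compound 2, but on a core that differs from that of compound 1 by nitro in place of hydrogen on an aromatic carbon. Should that change carry over, the step from compound 3 to compound 4 in this assay is expected to be about a number 11 percentage points higher from compound 3 to compound 4 (beyond the scatter), resting on the earlier step of a number 11.4 percentage points higher from compound 1 to compound 2 (beyond the scatter). Compound 4 is therefore estimated at 40%, between 30% and 52%.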

Compound 4, a percentage reported as inhibition, in the whole organism at one dose (the size of the read-out at that dose, not a potency): 55.3%
Estimate against measurement, compound 4: 15.3 percentage points below; measured number above the stated range.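

Sulfamoyl in place of hydrogen gives a step of a number 26.3 percentage points higher from compound 3 to compound 4 (beyond the scatter), so in this assay the change points the same way on the nitro-bearing core as on the core of compound 1, but its size does not carry over: the same change on two cores in this assay, a number 11.4 percentage points higher (beyond the scatter) from compound 1 to compound 2 and a number 26.3 percentage points higher (beyond the scatter) from compound 3 to compound 4, 14.9 percentage points apart, beyond the scatter of two such steps

Seen from the other side, the nitro change lowers the number without sulfamoyl but gives a step of a number 0.5 percentage points higher from compound 2 to compound 4 (within the scatter) with it, so the two changes do not simply add: the same change on two cores in this assay, a number 14.4 percentage points lower (beyond the scatter) from compound 1 to compound 3 and a number 0.5 percentage points higher (within the scatter) from compound 2 to compound 4, 14.9 percentage points apart, beyond the scatter of two such steps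

This rests on one set of four compounds at a single dose, so it does not show how sulfamoyl would behave on any other core, nor why the steps differ.

Open, from the compounds shown here alone, is whether a carboxylic acid or an amine in place of sulfamoyl would behave the same way on these two cores. Also open, going by these compounds, is whether compound 2 and compound 4 would still match at other doses.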